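The source may report more compounds than this note shows. Statements on the series, on what has been measured and on what is new or still open speak of the compounds shown alone.

Compound 1 `CC(C)C(c1ncco1)c1ccc(-c2ccc3cccc(F)c3c2)[nH]c1=O` gives 24 nM in an assay on CHO cells for displacement of a labelled ligand from prostaglandin E2 receptor EP3 subtype (Homo sapiens), read by radioligand binding; a lower number here means a stronger inhibitor, a higher number a weaker inhibitor.
Compound 2 `CC(C)C(Cc1nnc[nH]1)c1ccc(-c2ccc3cccc(F)c3c2)[nH]c1=O` gives 10 nM in this assay.
Compound 3 `CCn1ncc2c(F)cc(-c3ccc(C(CC)(CC)c4nnc(C)[nH]4)c(=O)[nH]3)cc21` gives 34 nM in this assay.

Compound 2 has the lowest number of the three. Compound 1 is nearest to it and compound 3 furthest, and both gaps lie beyond the scatter. Compound 4 `Cc1c[nH]c(C(c2ccc(-c3ccc4cccc(F)c4c3)[nH]c2=O)C(C)C)n1` has not yet been measured. It differs from compound 2 in one place: 4-methyl-1H-imidazol-2-yl in place of (4H-1,2,4-triazol-3-yl)methyl on a saturated chain carbon bound to an aromatic carbon and a saturated chain carbon. Among the compounds with values here, only one measured step bears on this change: a 2.4-fold lower number from compound 1 to compound 2 (0.38 log units; beyond the scatter), in which the 1,3-oxazol-2-yl group gave way to the (4H-1,2,4-triazol-3-yl)methyl group. Compound 4 goes the other way, back to a five-membered aromatic ring joined to the chain carbon without the methyl link, so the step is expected to run partly back toward the number of compound 1. The expected change is a 2.0-fold higher number from compound 2 to compound 4 (0.30 log units; within the scatter). Compound 4 is therefore estimated at 20 nM, with a range from 8 nM to 50 nM.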

Compound 4, inhibition constant: 12 nM
Compound 4: the middle estimate sits 1.7-fold (0.22 log units) above what was measured, and the stated range covers the measured number.
By their numbers in this assay, from the lowest: compounds 2, 4, 1 and 3 (each within the scatter of the next, the first and the last beyond it).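

At this saturated chain carbon, the 4-methyl-1H-imidazol-2-yl group cannot be told apart from the (4H-1,2,4-triazol-3-yl)methyl group (see a 1.2-fold higher number from compound 2 to compound 4 (0.08 log units; within the scatter)), even though it has no methyl link and carries 1 hydrogen-bond acceptor against 2. It also cannot be told apart from the 1,3-oxazol-2-yl group (see a 2.0-fold lower number from compound 1 to compound 4 (0.30 log units; within the scatter)), so compound 4 falls within the scatter of both compound 1 and compound 2, although those two differ from each other by more than the scatter. Nothing shown explains why these groups give such close numbers.

It remains open whether the methyl on the imidazole ring contributes, since the unmethylated 1H-imidazol-2-yl group is not among these compounds. On these data alone, how a carboxylic acid or an amine would behave on this same carbon also remains open.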